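Selenium-ring nucleosides: amino substitution on the second epimer

The source may hold more compounds than are shown below. What is called first, only, known or untested is meant among the compounds shown, and "the series" means these compounds.

Compound 1 `OC[C@H]1O[C@@H](n2cnc3c(O)ncnc32)C[Se]1`, compound 2 `Nc1nc(O)c2ncn([C@H]3C[Se][C@@H](CO)O3)c2n1` and compound 3 `OC[C@H]1O[C@H](n2cnc3c(O)ncnc32)C[Se]1` share the same core. In a functional assay on CCRF-CEM cells (Homo sapiens) for cytotoxicity (a lower number here means a stronger inhibitor, a higher number a weaker inhibitor), compound 1 gives > 100000 nM, a limit of the assay. Compound 2 gives > 100000 nM in this assay, again a limit. Compound 3 stands at > 100000 nM in this assay, also a limit. Both measured steps, a step that the two limits leave unreadable from compound 1 to compound 2 and a step that the two limits leave unreadable from compound 1 to compound 3, cannot be sized because of the limit of > 100000 nM in this assay, at which 3 of the 3 values shown sit. Compound 4 `Nc1nc(O)c2ncn([C@@H]3C[Se][C@@H](CO)O3)c2n1` carries the change (amino in place of hydrogen on an aromatic carbon). The amino step that the two limits leave unreadable from compound 1 to compound 2 is the one that bears on it, and it gave no readable size. Compound 4 is therefore expected to sit at the limit again, with the step of a number no higher from compound 3 to compound 4 (the limit leaves the size open) expected to show nothing beyond the scatter. Compound 4 is estimated at 100000 nM, between 30000 nM and 300000 nM.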

Compound 4, half-maximal inhibitory concentration: > 100000 nM
Compound 4 ended at the assay's limit; the forecaster's own chance of this, stated with the estimate: 85%; the middle value lies on the limit itself.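

Neither new step, from compound 3 to compound 4 or from compound 2 to compound 4, can be read: the limit of > 100000 nM in this assay, at which 4 of the 4 values shown sit.

From the compounds shown here alone, whether the amino group or the drawn configuration changes the read-out in this assay stays open.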